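The source may hold more compounds than are shown below. What is called first, only, known or untested is meant among the compounds shown, and "the series" means these compounds.

Of the compounds shown here, two built on a shared core have so far been read in a functional assay on HL-60 cells (Homo sapiens) for antiproliferative activity, read by MTT assay, with a stated time of 72 h (on this read-out higher numbers stand for weaker inhibition and lower numbers for stronger inhibition), and give a first view of the series. Compound 1 (`CNc1nc(-c2cc(OC)c(OC)c(OC)c2)c(-c2ccc3ccccc3c2)s1`) gives 143 nM and compound 2 (`CNc1nc(-c2cc(OC)c(OC)c(OC)c2)c(-c2ccc(C)cc2)s1`) gives 18.1 nM in this test. Compound 2 therefore holds the lower of the two numbers, with a gap beyond the scatter, and is the stronger inhibitor of the pair. Compound 3 (`CNc1nc(-c2cc(OC)c(OC)c(OC)c2)c(-c2ccc(C(F)(F)F)cc2)s1`) has not yet been measured. It carries trifluoromethyl in place of methyl on an aromatic carbon, para to a large group (trifluoromethyl in place of methyl on an aromatic carbon). Among the compounds with values here, no measured pair of compounds isolates a change of this kind, so the data offer no direct precedent. The expectation starts from compound 2 at 18.1 nM and is a judgement, not a measured trend. Inhibition is expected to weaken, by a margin beyond the scatter. The estimated change is a 6.6-fold higher number from compound 2 to compound 3 (0.82 log units; beyond the scatter) in the direction of higher numbers. The estimate for compound 3 is 120 nM with an expected range from 30 nM to 500 nM in this measurement.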

Compound 3, half-maximal inhibitory concentration: 3170 nM
Beside the measured number, compound 3's estimate is 26-fold (1.42 log units) below it; measured number above the stated range.
By their numbers in this assay, from the lowest: compound 2; then compound 1; then compound 3.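

In this assay, trifluoromethyl in place of methyl on the aromatic carbon para to a large group gives a 180-fold higher number from compound 2 to compound 3 (2.24 log units; beyond the scatter), a large step and the first in this series that isolates one change. It shows that this position does not treat all groups alike: methyl and trifluoromethyl both lack a ring, hydrogen-bond donors, hydrogen-bond acceptors and net charge, yet the two compounds stand far apart on this read-out. No independent evidence is available to explain the size of this step.

The compounds shown leave open how other groups at this place would read, such as a fluorine or chlorine atom, a methoxy group or an ethyl chain, and whether any of them would stay close to compound 2 or fall towards compound 3. As far as these compounds go, it also remains open how an amine or a carboxylic acid would read at this place, and whether the same exchange would give a step of similar size elsewhere on the shared core.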